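The compounds below may be only part of what the source reports. "The series", "measured", "known", "first", "only" and "open" are said of these compounds alone.

Measured compounds:
compound 1 `CSc1nn(-c2ccccc2)c2nc(Nc3ccccc3)n(-c3ccccc3)c(=O)c12`: 25.4%
compound 2 `CSc1nn(-c2ccc([N+](=O)[O-])cc2)c2nc(Nc3ccccc3)n(-c3ccccc3)c(=O)c12`: 26.6%

In a functional assay on the whole organism (strain Wistar albino) for inhibition, with Rattus norvegicus as the target, read by paw edema, with a stated time of 3 h, at a dose of 25 mg/kg by the oral route (on this read-out lower numbers stand for less inhibition and higher numbers for more inhibition at the one dose given (going by the name of the read-out)), compound 2 gives 26.6%, and compound 1 gives 25.4%; the two numbers lie within the scatter of each other, so compound 2 stands level with compound 1 rather than apart from it. Compound 3 `CSc1nn(-c2ccc(S(N)(=O)=O)cc2)c2nc(Nc3ccccc3)n(-c3ccccc3)c(=O)c12` is the next compound. It differs from compound 2 in one place: sulfamoyl in place of nitro on an aromatic carbon. Within the data shown here, the only measured step that bears on this place is the one from compound 1 to compound 2, which put a nitro group on the same aromatic carbon, and it read a number 1.2 percentage points higher from compound 1 to compound 2 (within the scatter), within the scatter. A change at this position has therefore not yet moved this assay beyond its scatter, and no step beyond the scatter is expected from compound 2 to compound 3 either. The step expected from compound 2 to compound 3 is a number 1.4 percentage points higher from compound 2 to compound 3 (within the scatter). For compound 3 the expected value in this assay is 28%, with a range from 16% to 40%.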

Compound 3, a percentage reported as inhibition, in the whole organism at one dose (the size of the read-out at that dose, not a potency): 35.2%
Beside the measured number, compound 3's estimate is 7.2 percentage points below it; the range from low to high includes it.
By their numbers in this assay, from the lowest: compounds 1, 2 and 3 (each within the scatter of the next).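

In this assay the exchange of nitro for sulfamoyl gives a number 8.6 percentage points higher from compound 2 to compound 3 (within the scatter) and the exchange of hydrogen for sulfamoyl gives a number 9.8 percentage points higher from compound 1 to compound 3 (within the scatter) on this same aromatic carbon. A second group here, one that carries a hydrogen-bond donor where nitro carries none, therefore still does not separate from either nitro or hydrogen, so the three compounds cannot be placed in an order at this single dose. Nothing available explains these numbers.

Going by these compounds, whether an amine, a carboxylic acid or a longer chain on this carbon would move the read-out beyond its usual scatter stays open. Also open, on these data alone, is how these compounds would compare at other doses, and whether changes elsewhere on the shared core matter more than changes at this position.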